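Trifluoromethyl Replaced by a Sulfonamide: Cytotoxicity Outlook

The source may report more compounds than this note shows. Statements on the series, on what has been measured and on what is new or still open speak of the compounds shown alone.

The three measured compounds share one core and differ only in the aryl group on the amide-type nitrogen in the ring. Compound 1 `COc1ccc([C@H]2CC(=O)N(c3cccc(N)c3C)C2)cc1OC1CCCC1` carries 3-amino-2-methylphenyl there, compound 2 `COc1ccc([C@H]2CC(=O)N(c3ccc(C#N)cc3)C2)cc1OC1CCCC1` carries 4-cyanophenyl, and compound 3 `COc1ccc([C@H]2CC(=O)N(c3cccc(C(F)(F)F)c3)C2)cc1OC1CCCC1` carries 3-(trifluoromethyl)phenyl. In a functional assay on HEK293 cells (Homo sapiens) for cytotoxicity (on this read-out higher numbers stand for lower toxicity in this test and lower numbers for higher toxicity in this test), compound 1 gives > 10000 nM, which is a limit of the assay rather than a number. Compound 2 also returns only a limit in this assay, > 10000 nM. Compound 3 likewise stands at a limit in this assay, > 10000 nM, so its position among the three cannot be ranked. For the measured compounds named here, because the limit of > 10000 nM in this assay, at which 3 of the 3 values shown sit, none of the measured steps can be read: a step that the two limits leave unreadable from compound 1 to compound 2, a step that the two limits leave unreadable from compound 1 to compound 3 and a step that the two limits leave unreadable from compound 2 to compound 3 are all of unknown size.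

Compound 4 `COc1ccc([C@H]2CC(=O)N(c3cccc(NS(=O)(=O)c4cccc(Cl)c4C)c3)C2)cc1OC1CCCC1` differs from compound 3 by ((3-chloro-2-methylphenyl)sulfonyl)amino in place of trifluoromethyl on an aromatic carbon. Going by the values given here, no measured step involves this group, and the three unreadable steps supply no size to compare against; what can be said is that every aryl variation tried so far left the read-out at the limit. Compound 4 is therefore expected to give 10000 nM, with a range from 3000 nM to 30000 nM. That estimate means a step of a number no higher from compound 3 to compound 4 (the limit leaves the size open), which is expected to stay within the scatter.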

Compound 4, half-maximal cytotoxic concentration: > 10000 nM
Compound 4: only a limit was reported; the forecaster's own chance of this, stated with the estimate: 65%; the middle value lies on the limit itself.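

In this assay compound 4 gives > 10000 nM, which is a limit of the assay and not a number. No size can be read for the change from compound 3 to compound 4, because every value shown rests on the same limit: the limit of > 10000 nM in this assay, at which 4 of the 4 values shown sit.

The compounds shown leave open how far apart any of them truly lie and whether any aryl group changes cytotoxicity.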